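A few compounds are considered here, and "the series" means these few. Any claim that something is new, unique, unknown or untested is made for them only; others in the source may bear on it.

Measured compounds in a physicochemical assay for lipophilicity; on this read-out higher numbers stand for higher lipophilicity and lower numbers for lower lipophilicity:
- compound 1 `CN1CCN(CCCS(=O)(=O)c2ccc3nc(NC(=O)NC(=O)c4cc(C5CC5)ccc4Cl)sc3c2)CC1` gives 2.9
- compound 2 `CS(=O)(=O)c1ccc2sc(NC(=O)NC(=O)c3ccccc3Cl)nc2c1` gives 2.8
- compound 3 `CN1CCC(S(=O)(=O)c2ccc3nc(NC(=O)NC(=O)c4cc(N5CCCC5)c(C#N)cc4Cl)sc3c2)CC1` gives 3

Of the compounds shown here, three sharing one core have been measured so far, and their numbers sit close together. Compound 1 stands second highest of the three; its nearest neighbour is compound 2, a little lower, and the furthest is compound 3, a little higher, yet both of these gaps lie within the scatter of repeated measurements, so no order among the three can be read from these values. Among the compounds with values here, no pair of the measured compounds differs in a single place, so no measured step is available to lean on.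

The unmeasured compound 4 `CN1CCN(CCCS(=O)(=O)c2ccc3nc(NC(=O)NC(=O)c4cc(-n5cccn5)ccc4Cl)sc3c2)CC1` departs from compound 1 in one place: 1H-pyrazol-1-yl in place of cyclopropyl on an aromatic carbon. The change sits on an aromatic carbon of a six-membered aromatic ring of carbon only, meta to a large group and para to a chloro group, and reads 2-chloro-5-cyclopropylphenyl to 2-chloro-5-(1H-pyrazol-1-yl)phenyl when cut one bond further out. Within the data shown here, with no measured step to guide the size, the step is expected to be a moderate decrease in this assay, beyond the scatter, amounting to a number 0.60 log units lower from compound 1 to compound 4 (beyond the scatter). Compound 4 is therefore estimated at 2.3, expected to fall between 1.8 and 2.8.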

Compound 4, distribution coefficient: 2
Compound 4: middle estimate off by 0.30 log units, on the high side; low and high end bracket the measured number.
By their numbers in this assay, from the lowest: compound 4; then compounds 2, 1 and 3 (each within the scatter of the next).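

In this assay, the aromatic carbon meta to a large group and para to a chloro group proves sensitive to what it carries: 1H-pyrazol-1-yl in place of cyclopropyl gives a number 0.90 log units lower from compound 1 to compound 4 (beyond the scatter). Within the data shown here, this is the first single-place step, something the earlier compounds could not offer, since they differ from one another in several places and their values lie within the scatter. The step also shows that, in this one pair, the number falls even though the entering group is the larger, with more heavy atoms and more hydrogen-bond acceptors than the group it replaces, and nothing at hand explains the size of this fall.

A single pair cannot separate the contribution of the ring nitrogens from that of the change from a three-membered non-aromatic ring to a five-membered aromatic one. From the compounds shown here alone, a pyrrol-1-yl or phenyl group at this position would bear on that question, and whether the same swap gives a similar step on a different side chain, such as the methylsulfonyl of compound 2, remains open.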